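This account rests on a few compounds, and the source may have more. Where it says the series, first, only, none or still open, it means among the compounds named here.

Compound 1 `Cc1ccc(S/C(=C/c2c[nH]c3ccccc23)C(=O)c2ccc(Br)cc2)cc1`: 10000 nM
Compound 2 `CSc1ccc(/C=C(/Sc2ccc(C)cc2)C(=O)c2ccc(Br)cc2)cc1`: 50000 nM
Compound 3 `Cc1ccc(S/C(=C/c2ccc(C)s2)C(=O)c2ccc(Br)cc2)cc1`: > 100000 nM

All three values come from a functional assay on DU-145 cells (Homo sapiens) for inhibition, read by trypan blue exclusion, with a stated time of 96 h; on this read-out higher numbers stand for weaker inhibition of growth and lower numbers for stronger inhibition of growth. Compound 3 stands at > 100000 nM, which is a limit of the assay and not a number.

Compound 4 `Cc1ccc(S/C(=C/c2ccc(F)cc2F)C(=O)c2ccc(Br)cc2)cc1` carries the change (2,4-difluorophenyl in place of 5-methylthiophen-2-yl on a double-bonded chain carbon bound to a double-bonded chain carbon). Two measured steps at this place bear on it. The first is an at least 2.0-fold higher number from compound 2 to compound 3 (0.30 log units; that floor lies within the scatter), and the second is an at least 10-fold higher number from compound 1 to compound 3 (1.00 log units; beyond the scatter). In both, 5-methylthiophen-2-yl gives the higher number. Compound 2, at 50000 nM, is the closest guide, with a six-membered aromatic ring at this place. A modest move towards stronger inhibition of growth is therefore expected, as an at least 2.5-fold lower number from compound 3 to compound 4 (0.39 log units; beyond the scatter). The estimate for compound 4 is 40000 nM, with an expected range from 10000 nM to 150000 nM.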

Compound 4, concentration for 50% growth inhibition: > 100000 nM
Compound 4 ended at the assay's limit (the forecaster's own chance of this, stated with the estimate: 30%); middle value at least 2.5-fold (0.39 log units) from the limit.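

Compound 4, with 2,4-difluorophenyl at this place, reads as a limit and not a number, and the step between compound 3 and compound 4 cannot be read. The change gives an at least 10-fold higher number from compound 1 to compound 4 (1.00 log units; beyond the scatter), which separates it clearly from the indole, while an at least 2.0-fold higher number from compound 2 to compound 4 (0.30 log units; that floor lies within the scatter) does not separate it from compound 2. A second group now sits at the same ceiling: the limit of > 100000 nM in this assay, at which 2 of the 4 values shown sit.

Open, on these data alone, is how far either limit compound lies from the measured ones. Also open, as far as these compounds go, is whether an amine or a carboxylic acid on the ring at this place would restore growth inhibition.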